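The source may hold more compounds than are shown below. What is called first, only, known or untested is meant among the compounds shown, and "the series" means these compounds.

The measured compounds:

Compound 1 `Cc1cccc(NC(=O)CN2CCC(c3ccc(O)cc3)CC2)c1` — 70 nM
Compound 2 `O=C(CN1CCC(c2cccc[n+]2[O-])CC1)Nc1cc(Cl)cc(Cl)c1` — 160 nM
Compound 3 `Cc1cccc(C(=O)NCN2CCC(c3cccc[n+]3[O-])CC2)c1` — 89 nM

In a functional assay on HEK293 cells for agonist activity at D(4) dopamine receptor (Homo sapiens), read by FLIPR (a lower number here means that less compound is needed, a higher number that more compound is needed for the effect), compound 1 gives 70 nM, the lowest of the three numbers; its gap to compound 3 lies within the scatter, while compound 2 sits beyond it. Compound 4 `Cc1cccc(NC(=O)CN2CCC(c3ccc(O)cn3)CC2)c1` has not yet been measured in this assay. It differs from compound 1 in one place: 5-hydroxypyridin-2-yl in place of 4-hydroxyphenyl on a saturated ring carbon. Among the measured compounds shown here, no comparable step between measured compounds is available, so the size of this change can only be guessed. Compound 4 is expected to land close to compound 1, with a step from compound 1 to compound 4 of a 1.7-fold higher number from compound 1 to compound 4 (0.23 log units; within the scatter), not beyond the scatter. The estimate for compound 4 is 120 nM, in a range from 40 nM to 400 nM.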

Compound 4, half-maximal effective concentration: 3.8 nM
The estimate for compound 4 lay 32-fold (1.50 log units) above the measured number; the whole stated range lies above it.
By their numbers in this assay, from the lowest: compound 4; then compounds 1, 3 and 2 (each within the scatter of the next, the first and the last beyond it).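

In this assay, the position three ring bonds from the ring nitrogen responds strongly to a small change: 5-hydroxypyridin-2-yl in place of 4-hydroxyphenyl gives an 18-fold lower number from compound 1 to compound 4 (1.27 log units; beyond the scatter) on the core of compound 1. Both groups hold 7 heavy atoms and 1 hydrogen-bond donor, but the entering ring has a nitrogen and 2 hydrogen-bond acceptors rather than 1. No measurement at hand explains the size of this step. As far as these compounds go, it remains open whether the ring nitrogen alone carries the step, or whether it needs the hydroxyl; a plain pyridin-2-yl or a methoxy in place of that hydroxyl would separate the two.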